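A few compounds are considered here, and "the series" means these few. Any claim that something is new, unique, unknown or untested is made for them only; others in the source may bear on it.

In an ADME assay on HepG2 cells (Homo sapiens) for cytotoxicity, read by resazurin assay, with a stated time of 24 h (on this read-out higher numbers stand for weaker inhibition and lower numbers for stronger inhibition), compound 1 (`COc1cc2[nH]c(C)c(-c3ccc(Oc4ccc(OC(F)(F)F)cc4)nc3)c(=O)c2cc1Cl`) gives > 10000 nM as its reading, which is a limit of the assay and not a number. Compound 2 (`COc1cc2[nH]c(C)c(-c3ccc(Oc4ccc(OC(F)(F)F)cc4)cn3)c(=O)c2cc1Cl`) gives > 10000 nM as its reading, again a limit. Compound 3 (`Cc1[nH]c2ccc(Cl)cc2c(=O)c1-c1ccc(Oc2ccc(OC(F)(F)F)cc2)nc1`) likewise reads > 10000 nM and so it too stands only at a limit. The whole set so far is summed up by the limit of > 10000 nM in this assay, at which 3 of the 3 values shown sit, and holds no readable number.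

Compound 4 (`Cc1[nH]c2ccccc2c(=O)c1-c1ccc(Oc2ccc(OC(F)(F)F)cc2)nc1`) has hydrogen in place of chloro on an aromatic carbon and is otherwise the same as compound 3. The nearest measured change, hydrogen in place of methoxy, is a step that the two limits leave unreadable from compound 1 to compound 3 and so offers no size to carry over. With nothing readable to go on, no step beyond the scatter is expected in this assay and no direction can be named. The expected change is a step that the limit leaves unreadable from compound 3 to compound 4 and it should be read as a rough guess. Compound 4 is estimated at 20000 nM with an expected range from 8000 nM to 50000 nM and the assay may well report only a limit again.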

Compound 4, half-maximal inhibitory concentration: > 10000 nM
Compound 4: no number, only a limit; the forecaster's own chance of this, stated with the estimate: 90%; the middle value does not contradict the limit.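

Compound 3 and compound 4 both stand only at a limit, so no readable step comes from putting hydrogen in place of chloro. The compounds shown leave open whether any of these changes shifts the reading in this assay at all, as the whole set rests on one reading: the limit of > 10000 nM in this assay, at which 4 of the 4 values shown sit.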